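Rearranging the Bicyclic Amine on the Shared Core

The compounds below may be only part of what the source reports. "The series", "measured", "known", "first", "only" and "open" are said of these compounds alone.

For the measured compounds named here, compound 2 `O=C(OC(C(F)(F)F)C(F)(F)F)N1CCN(Cc2ccc(C(F)(F)F)cc2N2[C@@H]3CC[C@H]2COC3)CC1` holds the lowest of the two numbers measured so far: in an assay on brain for inhibition of Monoglyceride lipase (Mus musculus), with a stated time of 30 min (on this read-out lower numbers stand for stronger inhibition and higher numbers for weaker inhibition), compound 2 gives 48 nM, while compound 1 `O=C(OC(C(F)(F)F)C(F)(F)F)N1CCN(Cc2ccc(C(F)(F)F)cc2N2CCCCC2)CC1` gives 130 nM. Compound 3 `O=C(OC(C(F)(F)F)C(F)(F)F)N1CCN(Cc2ccc(C(F)(F)F)cc2N2CC3COCC3C2)CC1` keeps the same atoms but joins them differently: a group of 8 heavy atoms (6 carbon, 1 nitrogen, 1 oxygen; 2 five-membered non-aromatic rings with 1 hetero atom each) in place of a group of 8 heavy atoms (6 carbon, 1 nitrogen, 1 oxygen; one five-membered non-aromatic ring with 1 hetero atom, one six-membered non-aromatic ring with 2 hetero atoms), on an aromatic carbon. Going by the values given here, the only measured step, a 2.7-fold lower number from compound 1 to compound 2 (0.43 log units; beyond the scatter), concerns a different exchange at the same place, so it gives only a rough sense of how much a change there can move the number. The step of a 1.5-fold higher number from compound 2 to compound 3 (0.16 log units; within the scatter) is therefore expected to stay within the scatter. The estimate for compound 3 is 70 nM, within 25 nM to 200 nM.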

Compound 3, half-maximal inhibitory concentration: 17 nM
Estimate against measurement, compound 3: 4.1-fold (0.61 log units) above; the measured number lies below the stated range.
By their numbers in this assay, from the lowest: compound 3; then compound 2; then compound 1.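

Joining the same atoms differently gives a 2.8-fold lower number from compound 2 to compound 3 (0.45 log units; beyond the scatter), so at this place on the aromatic ring the way the rings are built matters, and not only which atoms they contain. The group with two five-membered rings also improves on the single six-membered ring, with a 7.6-fold lower number from compound 1 to compound 3 (0.88 log units; beyond the scatter). Nothing available explains why this arrangement gives the lower number. As far as these compounds go, it remains open whether an amine nitrogen in place of the ring oxygen would keep this gain, or whether a hydroxyl group added to the five-membered rings would.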